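Propyl for isopropyl in the hydroxamic acid series

A few compounds are considered here, and "the series" means these few. Any claim that something is new, unique, unknown or untested is made for them only; others in the source may bear on it.

Measured in a functional assay on PC-3 cells (Homo sapiens) for antiproliferative activity, read by MTT assay, with a stated time of 48 h (a lower number here means a stronger inhibitor of growth, a higher number a weaker inhibitor of growth), so far:
compound 1 `CCCCCN(Cc1ccc(C(=O)NO)cc1)c1ncc(-c2ccc(C)cc2)s1` gives 5060 nM
compound 2 `Cc1ccc(-c2cnc(N(Cc3ccc(C(=O)NO)cc3)C(C)C)s2)cc1` gives 1150 nM

Of the two measured compounds, compound 2 has the lower number at 1150 nM and stands apart from compound 1 beyond the scatter. The next compound to consider is compound 3 `CCCN(Cc1ccc(C(=O)NO)cc1)c1ncc(-c2ccc(C)cc2)s1` with the change propyl in place of isopropyl on a nitrogen on an aromatic ring and thus propyl in place of isopropyl on a nitrogen on an aromatic ring. Among the compounds with values here, the only measured step that bears on this is a 4.4-fold lower number from compound 1 to compound 2 (0.64 log units; beyond the scatter) and it is modest, with isopropyl in place of pentyl. Within the data shown here, that step alters both chain length and branching, and no measured pair separates the two. Propyl is unbranched like the pentyl of compound 1 but shorter, so it offers only a loose guide. A small move toward a higher number seems most likely. What is expected in this assay is a 1.7-fold higher number from compound 2 to compound 3 (0.24 log units; within the scatter) and so no clear move beyond the scatter. Compound 3 is estimated at 2000 nM with an expected range from 900 nM to 4800 nM in this series.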

Compound 3, concentration for 50% growth inhibition: 9160 nM
For compound 3 the middle estimate is 4.6-fold (0.66 log units) below the measured one; measured number outside the range, above it.
By their numbers in this assay, from the lowest: compound 2; then compounds 1 and 3 (each within the scatter of the next).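

In this assay, the arrangement of three carbons on a nitrogen on an aromatic ring matters at this position: with the same atoms joined differently, there is an 8.0-fold higher number from compound 2 to compound 3 (0.90 log units; beyond the scatter), so isopropyl and propyl cannot be treated as interchangeable here. Among the unbranched chains, there is a 1.8-fold higher number from compound 1 to compound 3 (0.26 log units; within the scatter), so going from pentyl to propyl gives no readable change, and compound 2 alone stands apart from the other two compounds, beyond the scatter of each; the earlier gain from pentyl to isopropyl therefore cannot be credited to the shorter chain alone. No measurement at hand explains the gap between the isomeric chains.

With isopropyl as the only branched group shown, it remains open whether the lower number in compound 2 extends to other branched groups such as tert-butyl or isobutyl, or to a ring such as cyclopropyl. Going by these compounds, it also remains open whether a shorter chain such as ethyl or methyl would stay level with compound 1 and compound 3 or move away from them.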